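Cytotoxicity in the series: the benzyl ether of compound 1

The source may report more compounds than this note shows. Statements on the series, on what has been measured and on what is new or still open speak of the compounds shown alone.

In an ADME assay on HEL cells (Homo sapiens) for cytotoxicity, with a stated time of 3 days (a higher number here means that more compound is tolerated, a lower number that less compound is tolerated), compound 1 `CCC1(Cc2ccccc2)OS(=O)(=O)C=C1OCCCCc1ccccc1` gives 99000 nM; this is the lowest of the two numbers in hand, and its nearest neighbour is compound 3 `CCC1(Cc2ccccc2)OS(=O)(=O)C=C1OCC=C(C)C` at 112000 nM, a step of a 1.1-fold higher number from compound 1 to compound 3 (0.05 log units; within the scatter). Compound 2 `CCC1(Cc2ccccc2)OS(=O)(=O)C=C1OCc1ccc([N+](=O)[O-])cc1` gives only a limit of the assay, < 200000 nM. The step from compound 1 to compound 2 is a step that the limit leaves unreadable from compound 1 to compound 2 owing to the limit of < 200000 nM in this assay, at which 1 of the 3 values shown sits. Compound 4 `CCC1(Cc2ccccc2)OS(=O)(=O)C=C1OCc1ccc(C)cc1` differs from compound 1 by 4-methylphenyl in place of 3-phenylpropyl on a saturated chain carbon bound to an oxygen on an unsaturated carbon. The one aryl replacement measured so far is unreadable, and the chain replacement stays within the scatter, so no step beyond the scatter is expected in this assay. Compound 4 is therefore estimated at 110000 nM in this assay, between 55000 nM and 220000 nM, which would mean an expected step of a 1.1-fold higher number from compound 1 to compound 4 (0.05 log units; within the scatter).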

Compound 4, half-maximal cytotoxic concentration: 41500 nM
The estimate for compound 4 lay 2.7-fold (0.42 log units) above the measured number; measured number below the stated range.
By their numbers in this assay, from the lowest: compound 4; then compounds 1 and 3 (each within the scatter of the next).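

At the saturated chain carbon bound to an oxygen on an unsaturated carbon, the replacing group can now be seen to matter in this assay: 4-methylphenyl gives a 2.4-fold lower number from compound 1 to compound 4 (0.38 log units; beyond the scatter) and a 2.7-fold lower number from compound 3 to compound 4 (0.43 log units; beyond the scatter). Among the compounds shown here, both steps are modest, yet this is the first readable change at this place to pass beyond the scatter, as 2-methylprop-1-en-1-yl in place of 3-phenylpropyl stayed within it.

From the compounds shown here alone, the steps involving compound 2 cannot be read: the limit of < 200000 nM in this assay, at which 1 of the 4 values shown sits. Whether an amine or a carboxylic acid in place of methyl on an aromatic carbon keeps the lower number stays open.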